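The source may hold more compounds than are shown below. What is called first, only, known or untested is meant among the compounds shown, and "the series" means these compounds.

Measured so far in an ADME assay on HEK293 cells (Homo sapiens) for inhibition, read by MTT assay, with a stated time of 3 days; on this read-out higher numbers stand for weaker inhibition and lower numbers for stronger inhibition:
compound 1 `C=CCOc1cc(/C=C\c2cc(OC)c(OC)c(OC)c2)ccc1OC` gives 43500 nM;
compound 2 `COc1ccc(COc2cc(/C=C\c3cc(OC)c(OC)c(OC)c3)ccc2OC)cc1` gives 64000 nM;
compound 3 `COc1ccc(/C=C\c2cc(OC)c(OC)c(OC)c2)cc1OCCC/C=C/c1ccc(F)cc1` gives 115000 nM.

Compound 2 stands second highest of the three numbers. Its nearest neighbour is compound 1, from which it differs by a 1.5-fold higher number from compound 1 to compound 2 (0.17 log units; within the scatter), a step within the scatter; the furthest is compound 3, reached by a 1.8-fold higher number from compound 2 to compound 3 (0.25 log units; within the scatter), also within the scatter. Compound 4 `COc1ccc(/C=C\c2cc(OC)c(OC)c(OC)c2)cc1OCCC/C=C/c1ccc(Br)cc1` has not yet been measured. Relative to compound 2 it differs by a group of 11 heavy atoms (10 carbon, 1 bromine; one six-membered aromatic ring of carbon only) in place of a group of 8 heavy atoms (7 carbon, 1 oxygen; one six-membered aromatic ring of carbon only), on a saturated chain carbon bound to an oxygen on an aromatic ring.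

For the measured compounds named here, two measured steps bear on this change. The step from compound 2 to compound 3 , which installs the closely related 4-(4-fluorophenyl)but-3-en-1-yl group in the same place, is a 1.8-fold higher number from compound 2 to compound 3 (0.25 log units; within the scatter). The step from compound 1 to compound 3 , a 2.6-fold higher number from compound 1 to compound 3 (0.42 log units; beyond the scatter), is modest but beyond the scatter. Compound 4 differs from compound 3 only in bromine in place of fluorine, so its number is expected close to that of compound 3, somewhat higher than compound 2. The expected step is a 1.9-fold higher number from compound 2 to compound 4 (0.27 log units; within the scatter). For compound 4 the estimate in this assay is 120000 nM, with a range from 50000 nM to 300000 nM.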

Compound 4, half-maximal inhibitory concentration: 55000 nM
The estimate for compound 4 lay 2.2-fold (0.34 log units) above the measured number; the range from low to high includes it.
By their numbers in this assay, from the lowest: compounds 1, 4, 2 and 3 (each within the scatter of the next, the first and the last beyond it).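

The new result shows that in this assay bromo in place of fluoro on an aromatic carbon is a readable change in its own right: a 2.1-fold lower number from compound 3 to compound 4 (0.32 log units; beyond the scatter). With bromine, the larger group on a saturated chain carbon bound to an oxygen on an aromatic ring no longer stands apart from the smaller ones, as a 1.2-fold lower number from compound 2 to compound 4 (0.07 log units; within the scatter) and a 1.3-fold higher number from compound 1 to compound 4 (0.10 log units; within the scatter) leave it indistinguishable from both 4-methoxyphenyl and vinyl. The gap between compound 1 and compound 3 therefore belongs to the fluoro compound and does not carry over to the bromo compound.

Nothing at hand explains why the two halogens differ. Going by these compounds, it also stays open where chloro on that aromatic carbon, or an amine in place of the whole group on the saturated chain carbon, would fall.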